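Anilino ring substitution on the shared core, fluoro step

A few compounds are considered here, and "the series" means these few. Any claim that something is new, unique, unknown or untested is made for them only; others in the source may bear on it.

Measured compounds:
Compound 1, `O=C1C=C(Nc2cccc(Cl)c2)C(=O)c2c1nc1n2[C@H]2OC[C@@H](O)[C@H]2OC1`: 1770 nM
Compound 2, `O=C1C(Nc2ccccc2)=CC(=O)c2c1nc1n2[C@H]2OC[C@@H](O)[C@H]2OC1`: 1830 nM
Compound 3, `CCOc1ccc(NC2=CC(=O)c3nc4n(c3C2=O)[C@H]2OC[C@@H](O)[C@H]2OC4)cc1`: 1110 nM

In a functional assay on MGC-803 cells (Homo sapiens) for inhibition, read by sulforhodamine B assay (a lower number here means a stronger inhibitor, a higher number a weaker inhibitor), compound 2 gives the highest of the three numbers, yet its gap to compound 1 and to compound 3 lies within the scatter, so no order among them is claimed. Compound 4, `O=C1C(Nc2cccc(F)c2)=CC(=O)c2c1nc1n2[C@H]2OC[C@@H](O)[C@H]2OC1`, differs from compound 2 by fluoro in place of hydrogen on an aromatic carbon, placed on an aromatic carbon meta to a large group. For the measured compounds named here, the one measured step that touches this ring, a 1.6-fold lower number from compound 1 to compound 3 (0.20 log units; within the scatter), stayed within the scatter; compound 1, carrying 3-chlorophenyl, and compound 2, carrying phenyl, show nearly the same values. A fluoro at that position is therefore expected to shift this assay by no more than the scatter, a 1.1-fold lower number from compound 2 to compound 4 (0.03 log units; within the scatter). Compound 4 is estimated at 1700 nM, range 900 nM to 3300 nM.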

Compound 4, half-maximal inhibitory concentration: 1470 nM
For compound 4 the middle estimate is 1.2-fold (0.06 log units) above the measured one; the range from low to high includes it.
By their numbers in this assay, from the lowest: compounds 3, 4, 1 and 2 (each within the scatter of the next).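

In this assay, the step of a 1.2-fold lower number from compound 2 to compound 4 (0.10 log units; within the scatter) is the first listed step that starts from the unsubstituted phenyl, and it places fluoro on an aromatic carbon meta to a large group. Even this direct replacement of hydrogen leaves the number within the scatter, so no order is claimed between the two compounds. No available measurement bears on the reason for this result.

Still open, from the compounds shown here alone, is whether an amine, a carboxylic acid or a longer chain at this position would take the number beyond the scatter.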